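Series notes: compound 2 to compound 3

The compounds below may be only part of what the source reports. "The series", "measured", "known", "first", "only" and "open" are said of these compounds alone.

Measured in a physicochemical assay for solubility, using the shake flask method, measured as kinetic solubility, with a stated time of 20 h, at pH 2; a lower number here means a less soluble compound, a higher number a more soluble compound:
- compound 1 `FC(F)(F)c1cccc(-c2nc3cnc(Nc4ccccn4)cc3[nH]2)c1`: 21000 nM
- compound 2 `COc1ccc(Nc2cc3[nH]c(-c4cccc(C(F)(F)F)c4)nc3cn2)nc1`: < 5000 nM (a limit)

Compound 2 has no number, only a limit: the limit of < 5000 nM in this assay, at which 1 of the 2 values shown sits. Compound 3 `FC(F)(F)c1cccc(-c2nc3cnc(Nc4cnccn4)cc3[nH]2)c1` differs from it as follows: pyrazin-2-yl in place of 5-methoxypyridin-2-yl on a nitrogen on an aromatic ring. For the measured compounds named here, the one measured step that bears on this is an at least 4.2-fold lower number from compound 1 to compound 2 (0.62 log units; beyond the scatter), which introduced the methoxy and lies beyond the scatter. From the compounds shown here alone, compound 3 carries no methoxy, so a higher number is expected in this assay, though the pyrazin-2-yl group itself is untested. The expected step is an at least 2.0-fold higher number from compound 2 to compound 3 (0.30 log units; that floor lies within the scatter). For compound 3 the estimate is 10000 nM, with an expected range of 3500 nM to 28000 nM.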

Compound 3, solubility: 155000 nM
Beside the measured number, compound 3's estimate is 16-fold (1.19 log units) below it, and the stated range ends below it.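

In this assay, for the compounds shown here, the group on a nitrogen on an aromatic ring can also raise the number: pyrazin-2-yl in place of pyridin-2-yl gives a 7.4-fold higher number from compound 1 to compound 3 (0.87 log units; beyond the scatter), whereas the only earlier step went down. Pyrazin-2-yl in place of 5-methoxypyridin-2-yl gives a wider step, an at least 31-fold higher number from compound 2 to compound 3 (1.49 log units; beyond the scatter), and that size is only a floor. Compound 2 carries a limit, not a number: the limit of < 5000 nM in this assay, at which 1 of the 3 values shown sits.

From the compounds shown here alone, the true size of that wider step stays open. So does how a pyrimidin-2-yl group, or a pyridin-2-yl group carrying a carboxylic acid, would read at this place.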